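The compounds below may be only part of what the source reports. "The series", "measured", "known", "first", "only" and "open" are said of these compounds alone.

Measured so far:
- compound 1, `O=C(CN1CCN(C2CCCCC2)CC1)Nc1nc2c(s1)CCCC2`: > 1000 nM
- compound 2, `O=C(CN1CCN(c2ccc(F)cc2)CC1)Nc1nc2c(o1)CCCC2`: 180 nM

Of the compounds shown here, two have been tested in an assay on isolated protein for inhibition of long-chain fatty acid transport protein 1 (Homo sapiens), read by scintillation counting, with a stated time of 20 min; a lower number here means a stronger inhibitor, a higher number a weaker inhibitor. For compound 1 the result is only a limit of the assay, > 1000 nM, so no exact number is known for it; the evidence amounts to the limit of > 1000 nM in this assay, at which 1 of the 2 values shown sits. Compound 2, which carries a fluorophenyl group on the ring nitrogen and an oxygen-containing core, gives 180 nM in this assay. Within the data shown here, no single-change step connects these two compounds, so their values stand side by side without a computed step.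

Compound 3, `O=C(CN1CCN(c2nccs2)CC1)Nc1nc2c(s1)CCCC2`, is not yet measured. It differs from compound 1 in one place: 1,3-thiazol-2-yl in place of cyclohexyl on an amine nitrogen in a ring. For compound 1 only a limit of the assay is known. The step of an at least 2.2-fold lower number from compound 1 to compound 3 (0.34 log units; beyond the scatter) is expected to run towards stronger inhibition, since compound 2, also bearing an aromatic group on that ring nitrogen, gives 180 nM. Compound 3 is therefore estimated at 450 nM, with a likely range from 120 nM to 2000 nM.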

Compound 3, half-maximal inhibitory concentration: 520 nM
Compound 3: middle estimate off by 1.2-fold (0.06 log units), on the low side; low and high end bracket the measured number.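

In this assay, placing 1,3-thiazol-2-yl instead of cyclohexyl on the amine nitrogen in a ring gives an at least 1.9-fold lower number from compound 1 to compound 3 (0.28 log units; that floor lies within the scatter). With the core of compound 1 unchanged, this nitrogen can carry a five-membered aromatic ring with 2 hetero atoms, and compound 3 gives an exact reading of 520 nM. The true size of the step remains unknown because compound 1 is known only through a limit of the assay: the limit of > 1000 nM in this assay, at which 1 of the 3 values shown sits.

The compounds shown leave open whether the nitrogen and sulfur of the thiazole ring matter, or whether a plain phenyl ring on the same nitrogen would do as well. They also leave open how an open chain such as butyl, or a small group such as methyl, would fare at this position.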